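Configuration step from compound 1 to compound 3

The source may report more compounds than this note shows. Statements on the series, on what has been measured and on what is new or still open speak of the compounds shown alone.

Among the compounds with values here, in a functional assay on DU-145 cells (Homo sapiens) for antiproliferative activity (on this read-out higher numbers stand for weaker inhibition and lower numbers for stronger inhibition), compound 1 (`COc1c(C)c2c(c(O)c1C/C=C(\C)CCC(=O)OC[C@@H]1O[C@H](n3cnc4c(N)ncnc43)[C@@H](O)[C@H]1O)C(=O)OC2`) gives 1500 nM as the only actual number so far. In this assay compound 2 (`COc1c(C)c2c(c(O)c1C/C=C(\C)CCC(=O)NC[C@H]1O[C@@H](n3cnc4c(N)ncnc43)[C@H](O)[C@@H]1O)C(=O)OC2`) reads > 100000 nM and that reading is a limit of the assay, not a number.

Compound 3 (`COc1c(C)c2c(c(O)c1C/C=C(\C)CCC(=O)OC[C@H]1O[C@@H](n3cnc4c(N)ncnc43)[C@H](O)[C@@H]1O)C(=O)OC2`) has yet to be measured and keeps the atoms and bonds of compound 1. The change (the two compounds have the same atoms and bonds and differ only in configuration as drawn: 4 of 5 stereo elements differ; a stereocentre at a saturated ring carbon is drawn S in compound 1 and R in compound 3; a stereocentre at a saturated ring carbon is drawn S in compound 1 and R in compound 3; a stereocentre at a saturated ring carbon is drawn S in compound 1 and R in compound 3; a stereocentre at a saturated ring carbon is drawn R in compound 1 and S in compound 3) is one of configuration as drawn only: three stereocentres at saturated ring carbons go from S to R, one goes from R to S, and the fifth stereo element stays as it is.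

Within the data shown here, no measured pair isolates a change of configuration, so any forecast here rests on little. With the same atoms and bonds as compound 1 at 1500 nM in view, no shift beyond the scatter is expected, though the margin on either side is wide. The estimated change is a 1.3-fold higher number from compound 1 to compound 3 (0.12 log units; within the scatter) on this thin basis. In this assay compound 3 is expected at 2000 nM within an estimated range from 300 nM to 15000 nM for the coming measurement.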

Compound 3, half-maximal inhibitory concentration: 5800 nM
Compound 3: the middle estimate sits 2.9-fold (0.46 log units) below what was measured; the range from low to high includes it.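

In this assay, the series now holds its first pair that isolates configuration: a 3.9-fold higher number from compound 1 to compound 3 (0.59 log units; beyond the scatter), a modest step that lies beyond the usual scatter. The step can be assigned to configuration as drawn, because no other structural change separates the pair: the fact that compounds 1 and 3 differ only in the configuration as drawn Configuration at the stereocentres on the saturated ring carbons therefore matters in this series, although compound 3 still gives a measurable 5800 nM, and with four stereo elements changing together, the pair does not show which of them carries the step.

Within the data shown here, compound 2 reads > 100000 nM in this assay, which is a limit of the assay and not a number, so no step involving it can be read. Still open, as far as these compounds go, is whether inverting a single stereocentre would reproduce any of this step, and how an ether or a longer chain in place of the ester linkage would read in each configuration.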